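This account rests on a few compounds, and the source may have more. Where it says the series, first, only, none or still open, it means among the compounds named here.

Measured compounds in an assay on adrenal medulla for inhibition of Vasopressin V2 receptor (Rattus norvegicus), read by radioligand binding; on this read-out higher numbers stand for weaker inhibition and lower numbers for stronger inhibition:
compound 1 `CN1CCN(CCCCOc2cc(C(=O)N3CCCCc4sccc43)ccc2NC(=O)c2ccccc2-c2ccccc2)CC1` with 7 nM;
compound 2 `CN(C)C1CCN(C(=O)COc2cc(C(=O)N3CCCCc4sccc43)ccc2NC(=O)c2ccccc2-c2ccccc2)CC1` with 4 nM;
compound 3 `O=C(Nc1ccc(C(=O)N2CCCCc3sccc32)cc1OCCCC(=O)N1CCC(N2CCCCC2)CC1)c1ccccc1-c1ccccc1` with 20 nM.

Compound 3 gives the highest of the three numbers in this assay, compound 1 being nearer to it and compound 2 furthest from it. Compound 4 `CN1CCCN(C(=O)CCCOc2cc(C(=O)N3CCCCc4sccc43)ccc2NC(=O)c2ccccc2-c2ccccc2)CC1` differs from compound 3 only in the amide attached to the chain: 4-methyl-1,4-diazepan-1-yl in place of 4-(piperidin-1-yl)piperidin-1-yl on a carbonyl carbon. Within the data shown here, the only measured single-site step, a 1.8-fold lower number from compound 1 to compound 2 (0.24 log units; within the scatter), swaps one chain-terminal amine for another and stays within the scatter, so it offers no firm guide here. Since compounds 1 and 2, which carry smaller basic termini, give lower numbers than compound 3, a modest move downward is expected for compound 4, a 2.0-fold lower number from compound 3 to compound 4 (0.30 log units; within the scatter), with the estimate for compound 4 at 10 nM (range 3 nM to 40 nM).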

Compound 4, half-maximal inhibitory concentration: 3 nM
For compound 4 the middle estimate is 3.3-fold (0.52 log units) above the measured one; the range from low to high includes it.
By their numbers in this assay, from the lowest: compounds 4, 2 and 1 (each within the scatter of the next, the first and the last beyond it); then compound 3.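

In this assay, the amide on the carbonyl carbon proves to matter, with a 6.7-fold lower number from compound 3 to compound 4 (0.82 log units; beyond the scatter) lying beyond the scatter when 4-methyl-1,4-diazepan-1-yl replaces 4-(piperidin-1-yl)piperidin-1-yl. Against the other chain-terminal groups the picture is less sharp, since a 1.3-fold lower number from compound 2 to compound 4 (0.12 log units; within the scatter) stays within the scatter, whereas a 2.3-fold lower number from compound 1 to compound 4 (0.37 log units; beyond the scatter) goes modestly beyond it. No evidence at hand explains these differences.

Still open, on these data alone, is whether a morpholine on the same carbonyl carbon would match compound 4, and whether the seven-membered ring or the methyl on its nitrogen carries the gain.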